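An Added Isopropyl on the Ester Aryl Ring

The source may report more compounds than this note shows. Statements on the series, on what has been measured and on what is new or still open speak of the compounds shown alone.

Compound 1 `CC(C)c1cccc(C(C)C)c1NS(=O)(=O)CC(=O)N(Cc1ccccc1)C(C)C` in an assay on microsomes from intestine for inhibition of acyl-CoA:cholesterol acyltransferase (Oryctolagus cuniculus) (on this read-out higher numbers stand for weaker inhibition and lower numbers for stronger inhibition), gives 150 nM. Compound 2 `CCCCCCCCOC(=O)CS(=O)(=O)Nc1c(C(C)C)cccc1C(C)C` in this assay reaches only the limit > 1000 nM. Compound 3 `CC(C)c1cccc(C(C)C)c1NS(=O)(=O)CC(=O)Oc1c(C(C)C)cccc1C(C)C` likewise sits at the limit > 1000 nM rather than at a number. Compound 3 thus stands at the limit of > 1000 nM in this assay, at which 2 of the 3 values shown sit, with no measured number to place it against compound 1. Compound 4 `CC(C)c1cc(C(C)C)c(OC(=O)CS(=O)(=O)Nc2c(C(C)C)cccc2C(C)C)c(C(C)C)c1` differs from compound 3 by isopropyl in place of hydrogen on an aromatic carbon. Among the measured compounds shown here, no step between two measured compounds exists to guide the size of this change. Because compound 3 already sits at the limit > 1000 nM, the step that the limit leaves unreadable from compound 3 to compound 4 is expected to be small or none beyond the scatter. Compound 4 is therefore estimated at 1500 nM, between 400 nM and 6000 nM.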

Compound 4, half-maximal inhibitory concentration: 2800 nM
The estimate for compound 4 lay 1.9-fold (0.27 log units) below the measured number, and the stated range covers the measured number.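

Among the compounds shown here, no step from compound 3 to compound 4 can be read, because the value of compound 3 is only a limit: the limit of > 1000 nM in this assay, at which 2 of the 4 values shown sit. The compounds shown leave open how much the added isopropyl groups of compound 4 change inhibition.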